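The source may report more compounds than this note shows. Statements on the series, on what has been measured and on what is new or still open speak of the compounds shown alone.

Compound 1 `COc1cccc(C(=O)Nc2cccc(C(=O)O)c2)c1` and compound 2 `CCCCOc1ccc(C(=O)Nc2cccc(C(=O)O)c2)cc1` share a core in which an amide links a substituted phenyl ring to a carboxylic acid-bearing aniline. In an assay on isolated protein for agonist activity at Bile acid receptor (Homo sapiens), read by TR-FRET, with a stated time of 3 h, in the absence of a further agent (a lower number here means that less compound is needed, a higher number that more compound is needed for the effect), compound 1 gives 1040 nM, while compound 2 gives 105 nM, the lowest of the two numbers obtained so far and a difference that lies beyond the usual scatter. Compound 3 `CC(C)COc1ccc(C(=O)Nc2cccc(C(=O)O)c2)cc1` has not yet been measured. It differs from compound 2 only in the shape of the alkoxy chain: isopropyl in place of propyl on a saturated chain carbon bound to an oxygen on an aromatic ring, so that butoxy becomes isobutoxy with the same count of carbons. Among the measured compounds shown here, no measured pair in this set reports what such a branching does, so there is no directly comparable step. A change of this kind is expected to move the number in this assay little, with no step beyond the scatter, or at most a modest rise. For compound 3 the estimated value is 180 nM, within a range of 70 nM to 500 nM, which corresponds to an expected step of a 1.7-fold higher number from compound 2 to compound 3 (0.23 log units; within the scatter).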

Compound 3, half-maximal effective concentration: 357 nM
Beside the measured number, compound 3's estimate is 2.0-fold (0.30 log units) below it, and the stated range covers the measured number.
By their numbers in this assay, from the lowest: compound 2; then compound 3; then compound 1.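

Branching is not neutral at this place: with the same count of carbons, the change from butoxy to isobutoxy gives a 3.4-fold higher number from compound 2 to compound 3 (0.53 log units; beyond the scatter) in this assay. Compound 1 and compound 2 differ in more than one place, so this is the first change on the saturated chain carbon bound to an oxygen on an aromatic ring that can be read on its own, and among these two compounds the unbranched butoxy chain gives the lower number. Nothing available explains the step.

The compounds shown leave open whether this cost of branching is particular to the isobutoxy chain or also holds for other branched chains. They also leave open how a longer straight chain or a cyclopropyl ring at the same place would compare with the butoxy chain of compound 2.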